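From phenoxy to chloro on a growth read-out

This account rests on a few compounds, and the source may have more. Where it says the series, first, only, none or still open, it means among the compounds named here.

Measured in a functional assay on HeLa cells (Homo sapiens) for inhibition, read by CellTiter-Glo, with a stated time of 48 h, in the presence of a further agent that is not named here; on this read-out higher numbers stand for weaker inhibition of growth and lower numbers for stronger inhibition of growth:
Compound 1 `CS(=O)(=O)Nc1ccccc1Nc1nc(Nc2ccc(C(=O)OCc3ccccc3)cc2)ncc1F`: 37000 nM
Compound 2 `CS(=O)(=O)Nc1ccccc1Nc1nc(Nc2ccc(Oc3ccccc3)cc2)ncc1F`: 7300 nM

Compound 2 holds the lower of the two numbers. Compound 3 `CS(=O)(=O)Nc1ccccc1Nc1nc(Nc2ccc(Cl)cc2)ncc1F` is related to it by chloro in place of phenoxy on an aromatic carbon. Among the compounds with values here, only one measured step bears on this change, at the same place: a 5.1-fold lower number from compound 1 to compound 2 (0.70 log units; beyond the scatter). On that single modest step, a step of similar size is expected in this assay, tentatively toward a higher number, though the data do not settle the direction. The expected change is a 2.5-fold higher number from compound 2 to compound 3 (0.39 log units; beyond the scatter). Compound 3 is estimated at 18000 nM, with an expected range of 5000 nM to 50000 nM.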

Compound 3, concentration for 50% growth inhibition: 23200 nM
Estimate against measurement, compound 3: 1.3-fold (0.11 log units) below; measured number inside the range.
By their numbers in this assay, from the lowest: compound 2; then compounds 3 and 1 (each within the scatter of the next).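

In this assay, the single chlorine atom gives a 3.2-fold higher number from compound 2 to compound 3 (0.50 log units; beyond the scatter) and so loses what phenoxy had gained at this position. Benzyloxycarbonyl and chloro show a 1.6-fold lower number from compound 1 to compound 3 (0.20 log units; within the scatter) and cannot be told apart on this read-out, which leaves phenoxy alone among the three groups. Nothing shown gives a reason for these steps. Going by these compounds, it remains open whether an amine or a carboxylic acid on this aromatic carbon would give a lower number than compound 2. On these data alone, it is also open whether a benzyloxy group would match phenoxy or chloro.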